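The source may hold more compounds than are shown below. What is called first, only, known or untested is meant among the compounds shown, and "the series" means these compounds.

Measured so far:
compound 1 `COc1ccc2c(=O)c(/C=C/C(=O)NCc3cccc(F)c3)coc2c1` — 28600 nM
compound 2 `Cc1ccccc1NC(=O)/C=C/c1coc2cc(O)ccc2c1=O` — 9320 nM

In a functional assay (QGY7701 cells, Homo sapiens) for inhibition, read by MTT assay, with a stated time of 48 h (a higher number here means a weaker inhibitor, a lower number a stronger inhibitor), compound 1 gives 28600 nM, the higher of the two numbers measured, and compound 2 gives 9320 nM, a gap beyond the usual scatter. Compound 3 `COc1ccc2c(=O)c(/C=C/C(=O)Nc3ccc(F)cc3)coc2c1` has not yet been measured. It differs from compound 1 in one place: 4-fluorophenyl in place of 3-fluorobenzyl on an amide-type nitrogen. Among the compounds with values here, no measured pair isolates this change, so the expectation rests only on the two compounds already measured. A modest move toward a lower number is expected for the step of a 1.9-fold lower number from compound 1 to compound 3 (0.28 log units; within the scatter). Compound 3 is therefore estimated to give 15000 nM in this assay, within 5000 nM to 45000 nM.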

Compound 3, half-maximal inhibitory concentration: > 100000 nM
Compound 3: a limit, no number (the forecaster's own chance of this, stated with the estimate: 10%); middle value at least 6.6-fold (0.82 log units) from the limit.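

On the amide-type nitrogen, the group matters: in this assay, 4-fluorophenyl in place of 3-fluorobenzyl gives an at least 3.4-fold higher number from compound 1 to compound 3 (0.54 log units; beyond the scatter). Compound 3 reads > 100000 nM, which is a limit of the assay and not a number. The full size of this step therefore cannot be read: the limit of > 100000 nM in this assay, at which 1 of the 3 values shown sits.

The swap alters both the link to the ring and the place of the fluorine, and the compounds shown do not separate the two. As far as these compounds go, how a plain benzyl or a longer chain such as 2-phenylethyl would read on this nitrogen also stays open.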